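The source may hold more compounds than are shown below. What is called first, only, known or untested is meant among the compounds shown, and "the series" means these compounds.

Measured so far in a functional assay on NCI-H226 cells (Homo sapiens) for inhibition, read by MTT assay, with a stated time of 48 h, tested at 10 uM; on this read-out lower numbers stand for less inhibition and higher numbers for more inhibition at the one concentration tested (going by the name of the read-out):
Compound 1 `Cc1ccc(Nc2cc(NC(=O)Nc3c(Cl)cccc3Cl)ncn2)cc1F` gives 40.7%.
Compound 2 `CCc1ccc(Nc2cc(NC(=O)Nc3cc(OC)cc(OC)c3)ncn2)cc1` gives 50.1%.
Compound 3 `Cc1cc(F)cc(Nc2cc(NC(=O)Nc3c(Cl)cccc3Cl)ncn2)c1` gives 78.1%.

Compound 2 stands second highest of these three numbers; its value sits within the scatter of compound 1 and well below compound 3. Compound 4 `COc1cc(NC(=O)Nc2cc(Nc3ccc(F)c(Cl)c3)ncn2)cc(OC)c1` differs from compound 2 in one place: 3-chloro-4-fluorophenyl in place of 4-ethylphenyl on a nitrogen on an aromatic ring. Among the compounds with values here, the only measured step at that same place is a number 37.4 percentage points higher from compound 1 to compound 3 (beyond the scatter), which shows that swapping the aryl group on that nitrogen can shift the read-out strongly. That step, however, was measured on a different urea partner, so its direction cannot simply be carried over. Compound 4 is therefore expected to stay near compound 2, with a step of a number 2.1 percentage points lower from compound 2 to compound 4 (within the scatter) in this assay, not beyond the scatter. The estimate for compound 4 is 48%, ranging from 22% to 74%.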

Compound 4, a percentage reported as inhibition, at one concentration (the size of the read-out at that concentration, not a potency): 36.7%
Compound 4: the middle estimate sits 11.3 percentage points above what was measured; the range from low to high includes it.
By their numbers in this assay, from the lowest: compounds 4, 1 and 2 (each within the scatter of the next, the first and the last beyond it); then compound 3.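

Swapping the aryl group on this nitrogen gives a number 13.4 percentage points lower from compound 2 to compound 4 (beyond the scatter) in this assay so this position also matters with a second urea partner, not only in the step of a number 37.4 percentage points higher from compound 1 to compound 3 (beyond the scatter). The two steps run in opposite directions, but they involve different aryl groups and different urea partners, so no single rule for this position follows. No measurement at hand gives a reason for either step. From the compounds shown here alone, it remains open how an amine or a carboxylic acid on this aryl ring would read, and whether 3-chloro-4-fluorophenyl would give a similar drop with the other urea partner.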